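This account rests on a few compounds, and the source may have more. Where it says the series, first, only, none or still open, it means among the compounds named here.

Values in a functional assay on HCT-116 cells (Homo sapiens) for inhibition, read by CCK-8 assay, with a stated time of 48 h (a higher number here means a weaker inhibitor, a lower number a stronger inhibitor), follow.
- Compound 1 `COc1cc(-c2ccnc3cc(-c4c[nH]c5ccccc45)nn23)cc(OC)c1OC`: 35 nM
- Compound 2 `COc1cc(-c2ccnc3cc(-c4ccc(Cl)cc4)nn23)cc(OC)c1OC`: 3340 nM
- Compound 3 `COc1cc(-c2ccnc3cc(-c4ccc(C)cc4)nn23)cc(OC)c1OC`: not yet measured

Of the two measured compounds, compound 2 has the higher number, at 3340 nM, and is therefore the weaker inhibitor. Going to compound 3 places methyl in place of chloro on an aromatic carbon, and the rest of the structure stays the same. For the measured compounds named here, only one measured step bears on this change: a 95-fold higher number from compound 1 to compound 2 (1.98 log units; beyond the scatter). That large step exchanges the whole 1H-indol-3-yl group for 4-chlorophenyl, so it says little about a swap on the phenyl ring itself. Going by the values given here, no measured step isolates such a swap, so no shift beyond the scatter is expected in this assay, and no direction is favoured. The expected change is a 1.1-fold lower number from compound 2 to compound 3 (0.05 log units; within the scatter). For compound 3 the estimate is 3000 nM, with an expected range of 1000 nM to 9000 nM.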

Compound 3, half-maximal inhibitory concentration: 48 nM
Estimate against measurement, compound 3: 63-fold (1.80 log units) above; the whole stated range lies above it.
By their numbers in this assay, from the lowest: compounds 1 and 3 (each within the scatter of the next); then compound 2.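

In this assay this position on the six-membered aromatic ring is highly sensitive: methyl in place of chloro gives a 70-fold lower number from compound 2 to compound 3 (1.84 log units; beyond the scatter) even though one heavy atom simply replaces another, with no change in ring count, hydrogen-bond donors, hydrogen-bond acceptors or net charge. The loss seen with 4-chlorophenyl therefore does not show that 1H-indol-3-yl is needed, since 4-methylphenyl in its place gives a 1.4-fold higher number from compound 1 to compound 3 (0.14 log units; within the scatter) and leaves the two groups unseparated in this assay. Nothing available explains the gap between chloro and methyl.

Going by these compounds, whether chloro is a specific liability or methyl a specific gain remains open, and the unsubstituted phenyl, fluoro, methoxy, ethyl or an amine at the same place would help separate these readings. On these data alone, whether a longer chain there is compatible with activity also remains open.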